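The source may report more compounds than this note shows. Statements on the series, on what has been measured and on what is new or still open speak of the compounds shown alone.

In a toxicity assay on Vero cells (Chlorocebus sabaeus) for inhibition (a lower number here means that less compound is needed, a higher number that more compound is needed for the effect), three compounds sharing one core have been measured so far, and none has given a number. Compound 1 `COc1cccc(NC(=O)c2nnn(Cc3ccc([S+](C)[O-])cc3)c2N)c1` gives > 50100 nM, which is a limit of the assay. Compound 2 `COc1cccc(NC(=O)c2nnn(Cc3ccc(C#N)cc3)c2N)c1` gives > 50100 nM, again a limit. Compound 3 `COc1cccc(NC(=O)c2nnn(CC3CCNCC3)c2N)c1` gives > 50100 nM, also a limit. Compound 3 therefore stands with the other two: the limit of > 50100 nM in this assay, at which 3 of the 3 values shown sit.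

Compound 4 `COc1cccc(NC(=O)c2nnn(Cc3ccccc3)c2N)c1` differs from compound 3 in one place: phenyl in place of piperidin-4-yl on a saturated chain carbon bound to an aromatic nitrogen. In other words, phenyl stands in place of piperidin-4-yl, so that (piperidin-4-yl)methyl becomes benzyl.

The closest measured change is a step that the two limits leave unreadable from compound 2 to compound 3, with piperidin-4-yl in place of 4-cyanophenyl on the same saturated chain carbon. Two other changes bear on it less directly: a step that the two limits leave unreadable from compound 1 to compound 3 and a step that the two limits leave unreadable from compound 1 to compound 2. None of these steps has a readable size. Still, compound 2 already carries an aromatic ring of carbon only on that chain carbon and gives > 50100 nM, a limit. No step beyond the scatter is therefore expected in this assay, in either direction. The expected step is a number no higher from compound 3 to compound 4 (the limit leaves the size open). For compound 4 the estimate is 50100 nM, with an expected range from 20000 nM to 100000 nM, and the assay may well report only a limit again.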

Compound 4, half-maximal effective concentration: > 50100 nM
Compound 4 ended at the assay's limit (the forecaster's own chance of this, stated with the estimate: 85%); the middle value lies on the limit itself.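

Compound 4 joins compound 1, compound 2 and compound 3 in this assay, and no step among these compounds can be read, since each result is a limit and not a number: the limit of > 50100 nM in this assay, at which 4 of the 4 values shown sit. The compounds shown leave open how much of any of them this assay would need for the effect.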